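Hydroxy to sulfanyl on the shared core

A few compounds are considered here, and "the series" means these few. Any claim that something is new, unique, unknown or untested is made for them only; others in the source may bear on it.

Measured so far:
compound 1 `CSc1ccc2c(c1)c(O)c(C(=O)N(C)c1ccccc1)c(=O)n2C` — 100%
compound 2 `COCn1c(=O)c(C(=O)N(C)c2ccccc2)c(O)c2cc(SC)ccc21` — 78%
compound 3 `CN(C(=O)c1c(O)c2cc([S+](C)[O-])ccc2n(C)c1=O)c1ccccc1` — 100%

In a functional assay on the whole organism for inhibition, with Mus musculus as the target, at a dose of 32 mg/kg by the oral route (a lower number here means less inhibition, a higher number more inhibition at the dose given (going by the name of the read-out)), compound 1 stands level with compound 3, the two together giving the highest numbers of the three. The step to compound 2, a number 22 percentage points lower from compound 1 to compound 2 (beyond the scatter), is the only one beyond the scatter; the step to compound 3, no change at the digits printed from compound 1 to compound 3 (within the scatter), stays within it.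

Compound 4 `CSc1ccc2c(c1)c(S)c(C(=O)N(C)c1ccccc1)c(=O)n2C` differs from compound 1 by sulfanyl in place of hydroxy on an aromatic carbon. Within the data shown here, no measured step touches the hydroxy itself: the step from compound 1 to compound 3 alters a group on a different aromatic carbon, and the step from compound 1 to compound 2 alters the chain on the ring nitrogen. Both steps only show that a change away from the hydroxy leaves the number where it is or lowers it modestly, and nothing in the series shows a number rising above that of compound 1. The step is therefore expected to be a lowering, a number 30 percentage points lower from compound 1 to compound 4 (beyond the scatter), with wide uncertainty. For compound 4 the estimate in this assay is 70%, between 35% and 100%.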

Compound 4, a percentage reported as inhibition, in the whole organism at one dose (the size of the read-out at that dose, not a potency): 19%
Beside the measured number, compound 4's estimate is 51 percentage points above it, outside the stated range (below it).
By their numbers in this assay, from the lowest: compound 4; then compound 2; then compounds 1 and 3 (each within the scatter of the next).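

In this assay, among these compounds, the hydroxy is the first place on the shared core where a single exchange removes most of the read-out (a number 81 percentage points lower from compound 1 to compound 4 (beyond the scatter)). The earlier steps shown here (a number 22 percentage points lower from compound 1 to compound 2 (beyond the scatter); no change at the digits printed from compound 1 to compound 3 (within the scatter)) changed only the chain on the ring nitrogen and the group on a different aromatic carbon, so this step alone shows that the aromatic carbon opposite the ring nitrogen does not accept every exchange, even one that keeps the printed counts of heavy atoms, donors and acceptors. Nothing at hand accounts for the gap between hydroxy and sulfanyl.

As far as these compounds go, whether the loss is specific to sulfanyl or follows any replacement of hydroxy stays open, and an amine or a fluorine on the same aromatic carbon would help separate the two. Also open, from the compounds shown here alone, is whether a longer chain on the ring nitrogen would shift the number for the sulfanyl compound.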